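Moving a methyl group around a benzyl ring in compound 3

A few compounds are considered here, and "the series" means these few. Any claim that something is new, unique, unknown or untested is made for them only; others in the source may bear on it.

Three compounds share one core and differ only in the aromatic ring carried on a saturated chain carbon bound to a nitrogen on an aromatic ring. In a functional assay on cells for positive allosteric modulation of G-protein coupled receptor 68 (Homo sapiens), read by a luciferase reporter and cAMP accumulation, with a stated time of 30 min, at pH 6.8 and pH 8.3, in the presence of a further agent that is not named here (on this read-out higher numbers stand for higher potency (the scale is a negative logarithm) and lower numbers for lower potency), compound 1 `Nc1nc(NCc2cccc(Cl)c2)nc(-c2ccccc2CO)n1` gives 4.97, compound 2 `Nc1nc(NCc2ccc(Cl)cc2)nc(-c2ccccc2CO)n1` gives 5.22 and compound 3 `Cc1ccccc1CNc1nc(N)nc(-c2ccccc2CO)n1` gives 4.7. Compound 3 has the lowest of the three numbers: the step of a number 0.27 log units lower from compound 1 to compound 3 (within the scatter) lies within the scatter, while the step of a number 0.52 log units lower from compound 2 to compound 3 (beyond the scatter) lies beyond it, so only compound 2 is clearly separated from compound 3.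

Compound 4 `Cc1cccc(CNc2nc(N)nc(-c3ccccc3CO)n2)c1` differs from compound 3 by a single change: 3-methylphenyl in place of 2-methylphenyl on a saturated chain carbon bound to a nitrogen on an aromatic ring. Going by the values given here, no measured pair shows exactly this methyl move. The closest guides are a number 0.25 log units higher from compound 1 to compound 2 (within the scatter), where the chlorine changes place without a clear effect, and a number 0.27 log units lower from compound 1 to compound 3 (within the scatter), where the ring type changes and the number again barely moves. A small shift, if any, is therefore expected, with the step of a number 0.20 log units higher from compound 3 to compound 4 (within the scatter) in this assay most likely within the scatter. The estimate for compound 4 is 4.9, with a range from 4.5 to 5.3.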

Compound 4, negative logarithm of the antagonist equilibrium constant: 4.4
Beside the measured number, compound 4's estimate is 0.50 log units above it; measured number below the stated range.
By their numbers in this assay, from the lowest: compounds 4, 3, 1 and 2 (each within the scatter of the next, the first and the last beyond it).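

In this assay, moving the methyl group gives a number 0.30 log units lower from compound 3 to compound 4 (within the scatter), so 2-methylphenyl and 3-methylphenyl cannot be told apart here. The change of group counts for more than this move: 3-methylphenyl in place of 3-chlorophenyl gives a number 0.57 log units lower from compound 1 to compound 4 (beyond the scatter), and in place of 4-chlorophenyl it gives a number 0.82 log units lower from compound 2 to compound 4 (beyond the scatter), both clear drops, although a number 0.27 log units lower from compound 1 to compound 3 (within the scatter) goes against any simple rule that methyl compounds fall clearly below chlorine compounds. Nothing available explains these differences.

The compounds shown leave open whether 4-methylphenyl would match the number of compound 2, which would tell whether the 4-position or the chlorine matters more. They also leave open how a methoxy group or an amine on this ring would compare with methyl and chloro.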